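Difluorophenyl in place of dichlorophenyl: compound 3

This account rests on a few compounds, and the source may have more. Where it says the series, first, only, none or still open, it means among the compounds named here.

In a functional assay on HCT-116 cells (Homo sapiens) for cytotoxicity, read by MTT assay, with a stated time of 48 h, in the presence of a further agent that is not named here (a higher number here means that more compound is needed for the effect, a lower number that less compound is needed), compound 1 `Cc1c(Cc2ccccc2)c(NNC(=O)Nc2cc(Cl)nc(Cl)c2)nc2c1cnn2C` gives 13600 nM and compound 2 `Cn1ncc2c(-c3ccc(F)cc3)cc(NNC(=O)Nc3cc(Cl)cc(Cl)c3)nc21` gives 39100 nM as the higher of the two numbers, a gap beyond the scatter. Compound 3 `Cn1ncc2c(-c3ccc(F)cc3)cc(NNC(=O)Nc3cc(F)cc(F)c3)nc21` carries 3,5-difluorophenyl in place of 3,5-dichlorophenyl on an amide-type nitrogen on the core of compound 2. Within the data shown here, no measured pair shows this change, so no step beyond the scatter is expected in this assay and the direction stays open. The estimated step of a 1.2-fold lower number from compound 2 to compound 3 (0.09 log units; within the scatter) is small and lies within the scatter. For compound 3 the estimate is 32000 nM with an expected range from 13000 nM to 80000 nM in this measurement.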

Compound 3, half-maximal effective concentration: 46200 nM
Compound 3: middle estimate off by 1.4-fold (0.16 log units), on the low side; low and high end bracket the measured number.
By their numbers in this assay, from the lowest: compound 1; then compounds 2 and 3 (each within the scatter of the next).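

Exchanging 3,5-dichlorophenyl for 3,5-difluorophenyl on the amide-type nitrogen gives a 1.2-fold higher number from compound 2 to compound 3 (0.07 log units; within the scatter) in this assay. On the core of compound 2, this assay therefore does not separate the two halogen pairs at this position. No supporting measurement bears on why the two groups read alike.

From the compounds shown here alone, whether an amine or a carboxylic acid on that phenyl ring would move the number remains open. Going by these compounds, it is also open whether the chlorine-to-fluorine exchange would read the same on another core.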